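The source may hold more compounds than are shown below. What is called first, only, known or untested is meant among the compounds shown, and "the series" means these compounds.

Compound 1 `C/C=C/C(=O)Nc1cccc(-c2nc3ccccc3s2)c1`: in an ADME assay on BJ cells (Homo sapiens) for inhibition, with a stated time of 72 h (on this read-out lower numbers stand for an effect already at smaller amounts and higher numbers for an effect only at larger amounts of compound), compound 1 gives > 25000 nM, which is a limit of the assay and not a number.
Compound 2 `O=C(CCl)Nc1cccc(-c2nc3ccccc3s2)c1`: in this assay compound 2 gives 8500 nM.

Compound 2 holds the only number shown for the series; the remaining value is the limit of > 25000 nM in this assay, at which 1 of the 2 values shown sits. Among the compounds with values here, the single measured step is an at least 2.9-fold lower number from compound 1 to compound 2 (0.46 log units; beyond the scatter), which replaces one acyl group by another on the carbonyl carbon of the shared core.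

Compound 3 `O=C(Nc1cccc(-c2nc3ccccc3s2)c1)c1ccncc1Cl` differs from compound 2 at the same position: 3-chloropyridin-4-yl in place of chloromethyl on a carbonyl carbon. Within the data shown here, the one measured step is the only guide, and neither of its ends carries an aromatic group on the carbonyl carbon, so it bears on this change only in showing that the acyl group moves the read-out by a modest amount. With the chloromethyl gone, compound 3 is expected to sit nearer the weaker side, a step estimated as a 2.1-fold higher number from compound 2 to compound 3 (0.33 log units; beyond the scatter). Compound 3 is therefore estimated at 18000 nM, ranging from 5000 nM to 40000 nM, with a fair chance that only a limit is reported.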

Compound 3, half-maximal effective concentration: > 25000 nM
Compound 3 was reported as a limit (the forecaster's own chance of this, stated with the estimate: 45%); middle value at least 1.3-fold (0.14 log units) away from the limit.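

With 3-chloropyridin-4-yl in place of chloromethyl on a carbonyl carbon, an at least 2.9-fold higher number from compound 2 to compound 3 (0.46 log units; beyond the scatter) shows that an aromatic acyl group at this position does not keep the read-out of compound 2. Within the data shown here, compound 2 therefore remains the only compound with a number in this assay, and its steps to both other acyl groups lie beyond the scatter. Compound 1 and compound 3 each stand at a limit of the assay, not at a number, and the step between them cannot be read: the limit of > 25000 nM in this assay, at which 2 of the 3 values shown sit.

From the compounds shown here alone, whether the number of compound 2 depends on the chlorine itself remains open, a question for a methyl or bromomethyl group on this carbonyl carbon. Also open, going by these compounds, is how a phenyl or unchlorinated pyridin-4-yl group would read here.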